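Moving the Acid Around a Pyridine Ring

The source may report more compounds than this note shows. Statements on the series, on what has been measured and on what is new or still open speak of the compounds shown alone.

Compound 1 `O=C(O)c1cncc(C2CC2c2ccc(OCc3c(-c4c(Cl)cccc4Cl)noc3C3CC3)cc2Cl)c1` is the reference point of this small set. Among the measured compounds shown here, in an assay on HEK293 cells for agonist activity at Bile acid receptor (Homo sapiens) (on this read-out lower numbers stand for an effect already at smaller amounts and higher numbers for an effect only at larger amounts of compound), compound 1 gives 14 nM, the lowest of the three numbers measured so far. Compound 2 `O=C(O)CNC(=O)c1ccc(C2CC2c2ccc(OCc3c(-c4c(Cl)cccc4Cl)noc3C3CC3)cc2Cl)cc1` gives 209 nM and compound 3 `CCO[C@]1(c2ccc(OCc3c(-c4c(Cl)cccc4Cl)noc3C3CC3)cc2Cl)C[C@H](c2cccc(C(=O)O)c2)C1` gives 220 nM; both lie beyond the usual scatter from compound 1, and neither differs from compound 1 in only one place. Compound 4 `O=C(O)c1ccc(C2CC2c2ccc(OCc3c(-c4c(Cl)cccc4Cl)noc3C3CC3)cc2Cl)cn1` has not been measured yet. It differs from compound 1 by 6-carboxypyridin-3-yl in place of 5-carboxypyridin-3-yl on a saturated ring carbon. For the measured compounds named here, no measured pair shows this kind of rearrangement, so the step has to be judged from the change alone: a modest weakening is expected, as a 2.1-fold higher number from compound 1 to compound 4 (0.33 log units; beyond the scatter), though it may still fall within the scatter. Compound 4 is thus expected to give 30 nM, most likely between 8 nM and 120 nM.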

Compound 4, half-maximal effective concentration: 57 nM
Compound 4: middle estimate off by 1.9-fold (0.28 log units), on the low side; measured number inside the range.
By their numbers in this assay, from the lowest: compound 1; then compound 4; then compounds 2 and 3 (each within the scatter of the next).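

Replacing 5-carboxypyridin-3-yl with 6-carboxypyridin-3-yl keeps the same atoms and only joins them differently, yet in this assay this change gives a 4.1-fold higher number from compound 1 to compound 4 (0.61 log units; beyond the scatter). Among the compounds shown here, at this place on the three-membered ring, the arrangement of the carboxypyridine therefore matters, not just its atoms, something the earlier compounds, which differ from compound 1 in more than one place, could not show. No measurement here explains the step. Still open, from the compounds shown here alone, is whether a phenyl ring bearing the carboxylic acid would match compound 1, or whether a tetrazole could replace the carboxylic acid on either pyridine.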